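Dichlorophenyl isomer swap on the ring amine nitrogen

The compounds below may be only part of what the source reports. "The series", "measured", "known", "first", "only" and "open" are said of these compounds alone.

Measured so far:
compound 1, `CC(C)N1CCN(Cc2csc(N)c2C(=O)c2ccc(Cl)cc2)CC1`: 0%
compound 2, `Nc1scc(CN2CCN(c3ccc(Cl)cc3Cl)CC2)c1C(=O)c1ccc(Cl)cc1`: 0%

In an assay on CHO cells for displacement of a labelled ligand from adenosine receptor A1 (Homo sapiens), read by scintillation counting, with a stated time of 120 min, tested at 10 uM (a lower number here means less inhibition, a higher number more inhibition at the concentration tested (going by the name of the read-out)), compound 1 gives 0% and compound 2 gives 0%; the step of no change at the digits printed from compound 1 to compound 2 (within the scatter) leaves compound 2 level with compound 1.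

Compound 3, `Nc1scc(CN2CCN(c3cccc(Cl)c3Cl)CC2)c1C(=O)c1ccc(Cl)cc1`, differs from compound 2 only in 2,3-dichlorophenyl in place of 2,4-dichlorophenyl on an amine nitrogen in a ring. For the measured compounds named here, the single measured step, no change at the digits printed from compound 1 to compound 2 (within the scatter), is the only one bearing on it, and it was flat despite a larger change at the same ring nitrogen. The step of a number 2 percentage points higher from compound 2 to compound 3 (within the scatter) is therefore expected to stay within the scatter. Compound 3 is estimated at 2%, range -8% to 15%.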

Compound 3, a percentage reported as inhibition, at one concentration (the size of the read-out at that concentration, not a potency): 2%
Beside the measured number, compound 3's estimate shows no gap at the digits printed; the measured number falls inside the stated range.
By their numbers in this assay, from the lowest: compounds 1, 2 and 3 (each within the scatter of the next).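

With 2,3-dichlorophenyl in place of 2,4-dichlorophenyl on the ring nitrogen, a number 2 percentage points higher from compound 2 to compound 3 (within the scatter) in this assay, so this swap between dichlorophenyl isomers does not register here. With 2,3-dichlorophenyl in place of isopropyl, a number 2 percentage points higher from compound 1 to compound 3 (within the scatter), so this position has now stayed flat across an alkyl group and two dichlorophenyl isomers. No available measurement accounts for these level values.

Still open, from the compounds shown here alone, is whether an acetyl group or a pyridyl ring on the same ring nitrogen would lift the inhibition in this assay beyond the scatter.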